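A few compounds are considered here, and "the series" means these few. Any claim that something is new, unique, unknown or untested is made for them only; others in the source may bear on it.

Compound 1, `COC(=O)C(C(=O)c1ccc(Cn2ccc3ccc(NC(=O)CC4CCCC4)cc32)c(OC)c1)S(=O)(=O)c1ccccc1`: 10.1
Compound 2, `CCCCC(CC)C(=O)Nc1ccc2ccn(Cc3c(OC)cc(C(=O)NS(=O)(=O)c4ccccc4)cc3OC)c2c1`: 8
Compound 3, `CCCCC(CC)C(=O)Nc1ccc2ccn(Cc3ccc(C(=O)NS(=O)(=O)c4ccc(OC)cc4)cc3OC)c2c1`: 7.4

All three compounds were tested in a functional assay (trachea) for antagonist activity, with Cavia porcellus as the target; on this read-out higher numbers stand for higher potency (the scale is a negative logarithm) and lower numbers for lower potency. In this assay compound 1 gives 10.1, compound 2 gives 8 and compound 3 gives 7.4. Compound 3 therefore has the lowest number of the three: compound 2 lies above it by more than the usual scatter, and compound 1 lies far above it. No pair among these three differs in one place only, so no single change has yet been tied to a measured step.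

Among the measured compounds shown here, compound 4, `CCCCC(CC)C(=O)Nc1ccc2ccn(Cc3ccc(C(=O)NS(=O)(=O)c4ccc(F)cc4)cc3OC)c2c1`, is the first such pair with compound 3. The change is fluoro in place of methoxy on an aromatic carbon; nothing else moves. For the measured compounds named here, with no measured step of this kind to lean on, the expectation is a small step, if any, and not beyond the scatter. The step expected here, a number 0.10 log units lower from compound 3 to compound 4 (within the scatter), is taken as essentially flat. Compound 4 is thus estimated to give 7.3, with a range from 6.7 to 7.9.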

Compound 4, negative logarithm of the antagonist equilibrium constant: 7.7
Compound 4: the middle estimate sits 0.40 log units below what was measured, within the range that was stated.
By their numbers in this assay, from the lowest: compounds 3, 4 and 2 (each within the scatter of the next, the first and the last beyond it); then compound 1.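

In this assay, among the compounds shown here, putting fluoro in place of methoxy on this aromatic carbon, para to a large group, gives a number 0.30 log units higher from compound 3 to compound 4 (within the scatter) as the first single change with a measured step in this set. This position therefore holds either group with no difference that can be told from the usual scatter of repeated measurements, even though the two groups share no atoms other than their link to the ring. For the compounds shown here, nothing measured so far speaks to why the two groups read alike.

From the compounds shown here alone, it remains open whether an amine, a carboxylic acid or a longer chain such as butoxy on this same carbon would also leave the number unmoved. One pair also cannot say whether fluoro and methoxy would read alike on the core of compound 1.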